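A few compounds are considered here, and "the series" means these few. Any claim that something is new, unique, unknown or untested is made for them only; others in the source may bear on it.

Compound 1 `CN(C)c1ccc(NS(=O)(=O)c2c(F)c(F)c(F)c(F)c2F)cc1`: 220 nM
Compound 2 `Cc1ccc(NS(=O)(=O)c2c(F)c(F)c(F)c(F)c2F)cc1C`: 220 nM
Compound 3 `O=S(=O)(Nc1ccc2c(c1)OCCO2)c1c(F)c(F)c(F)c(F)c1F`: 19 nM

All three numbers come from a functional assay on COLO 205 cells (Homo sapiens) for inhibition; on this read-out higher numbers stand for weaker inhibition of growth and lower numbers for stronger inhibition of growth. Compound 1 stands level with compound 2, and together they hold the highest of the three numbers. Compound 3 lies well below them, and that gap is clearly beyond the usual scatter of repeated measurements.

The next compound to be tested is compound 4 `COc1ccc(NS(=O)(=O)c2c(F)c(F)c(F)c(F)c2F)cc1`, which has not yet been measured. It keeps the core of compound 1 but carries methoxy in place of dimethylamino on an aromatic carbon, para to a large group: methoxy in place of dimethylamino on an aromatic carbon.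

Among the compounds with values here, no measured pair shows this swap on its own, so the data offer only indirect guidance. Within the data shown here, compound 3, at 19 nM, is the only measured compound with an ether oxygen, a feature that compound 4 also has. However, compound 3 differs from compound 4 in more than that one feature, so only part of its gap should carry over. In this assay, a moderate step towards a lower number is therefore expected, perhaps only just beyond the scatter. The expected change is a 2.8-fold lower number from compound 1 to compound 4 (0.44 log units; beyond the scatter). For compound 4 the estimate is 80 nM, with an expected range of 25 nM to 250 nM.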

Compound 4, concentration for 50% growth inhibition: < 10 nM
Compound 4: no number, only a limit; the forecaster's own chance of this, stated with the estimate: 2%; at least 8.0-fold (0.90 log units) between middle value and limit.
By their numbers in this assay, from the lowest: compound 3; then compounds 1 and 2 (each within the scatter of the next). At a limit, below all of these: compound 4.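

In this assay, putting methoxy in place of dimethylamino on the aromatic carbon, para to a large group, gives an at least 22-fold lower number from compound 1 to compound 4 (1.34 log units; beyond the scatter). Within the data shown here, this is the first direct sign that growth inhibition is sensitive to which small group sits at this position, even though the two groups have the same counts of hydrogen-bond donors and acceptors, and neither has a ring or a net charge. Compound 4 gives < 10 nM, which is a limit of the assay and not a number, so the step carries a limit too: the limit of < 10 nM in this assay, at which 1 of the 4 values shown sits.

The compounds shown leave open how much lower the true value of compound 4 lies and what in this swap produces so large a step, since a single exchange at this position cannot separate the change of atom from the change in group size. They also leave open whether other groups at the same place, such as ethoxy, a hydroxyl or a primary amine, would behave like methoxy or like dimethylamino.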